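A few compounds are considered here, and "the series" means these few. Any claim that something is new, unique, unknown or untested is made for them only; others in the source may bear on it.

Measured so far in a functional assay on DU-145 cells (Homo sapiens) for cytotoxicity, read by MTT assay, with a stated time of 24 h; on this read-out higher numbers stand for weaker inhibition and lower numbers for stronger inhibition:
compound 1 `NCCNC(=O)Cn1nc(N)c2c(C(F)(F)F)cc(-c3ccccc3)nc21` — 38900 nM
compound 2 `Nc1nn(CC(=O)NCCO)c2nc(-c3ccccc3)cc(C(F)(F)F)c12` — 96300 nM
compound 3 `Nc1nn(CC(=O)N2CCCCC2)c2nc(-c3ccccc3)cc(C(F)(F)F)c12` — 3200 nM

Compound 2 gives the highest number of the three, beyond the scatter from both others: from compound 1 the step was a 2.5-fold higher number from compound 1 to compound 2 (0.39 log units; beyond the scatter), and from compound 2 to compound 3 the step was a 30-fold lower number from compound 2 to compound 3 (1.48 log units; beyond the scatter).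

Compound 4 `CC(NC(=O)Cn1nc(N)c2c(C(F)(F)F)cc(-c3ccccc3)nc21)C(=O)O` is not yet measured. It differs from compound 2 at one place: 1-carboxyethyl in place of 2-hydroxyethyl on an amide-type nitrogen. The open chain on the amide-type nitrogen is kept, with one hydrogen-bond donor and one hydrogen-bond acceptor both before and after the change.

Among the measured compounds shown here, two measured steps bear on this. The step of a 2.5-fold higher number from compound 1 to compound 2 (0.39 log units; beyond the scatter) shows that swapping one polar end group of this chain for another moves the number only modestly. The steps of a 12-fold lower number from compound 1 to compound 3 (1.08 log units; beyond the scatter) and a 30-fold lower number from compound 2 to compound 3 (1.48 log units; beyond the scatter) show the large movement comes only when the chain is replaced by piperidin-1-yl; compound 4 does not take that route. The expectation for this assay is therefore a step from compound 2 of a 1.1-fold higher number from compound 2 to compound 4 (0.06 log units; within the scatter), in either direction but not beyond a modest size. Compound 4 is estimated at 110000 nM in this assay, with a range of 35000 nM to 350000 nM.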

Compound 4, half-maximal inhibitory concentration: 22400 nM
For compound 4 the middle estimate is 4.9-fold (0.69 log units) above the measured one, and the stated range ends above it.
By their numbers in this assay, from the lowest: compound 3; then compounds 4 and 1 (each within the scatter of the next); then compound 2.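

Within the open chains on the amide-type nitrogen, the count of hydrogen-bond donors and acceptors does not fix the number in this assay: 1-carboxyethyl and 2-hydroxyethyl have the same count, yet the change gives a 4.3-fold lower number from compound 2 to compound 4 (0.63 log units; beyond the scatter), while a 1.7-fold lower number from compound 1 to compound 4 (0.24 log units; within the scatter) leaves compound 4 and compound 1 not separable, so among the three open chains compound 2 alone stands apart. The 1-carboxyethyl chain also does not close the gap to the ring, with a 7.0-fold higher number from compound 3 to compound 4 (0.85 log units; beyond the scatter), and compound 3 keeps the lowest number in the set, beyond the scatter of all three open-chain compounds. Nothing available here explains these differences.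

The change from 2-hydroxyethyl to 1-carboxyethyl adds both a methyl branch and a carboxylic acid, so a carboxymethyl chain, or the methyl ester of 1-carboxyethyl, would be needed to tell which part goes with the step. From the compounds shown here alone, whether the ring itself or the absence of the amide hydrogen goes with the low number of compound 3 also stays open, and a pyrrolidine, a morpholine or a dimethylamino group on the carbonyl carbon would bear on that.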